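The source may report more compounds than this note shows. Statements on the series, on what has been measured and on what is new or still open speak of the compounds shown alone.

Compound 1: `COc1cc(C(=O)N2CCCC2)nn1-c1ccccc1`, 29.2%
Compound 2: `CCCCOc1cc(C(=O)NCC)nn1-c1ccccc1`, 0%

In a functional assay on the whole organism (strain Wistar) for inhibition, with Rattus norvegicus as the target, read by paw edema, with stated times of 30 min and 3 h, at a dose of 100 mg/kg by the oral route (a lower number here means less inhibition, a higher number more inhibition at the dose given (going by the name of the read-out)), compound 1 gives 29.2%, while compound 2 gives 0%, the lowest of the two numbers. The gap between them lies beyond the scatter, but the two compounds differ in more than one place, so these figures alone do not tell which change carries the difference. Compound 3, `CCCCOc1cc(C(=O)N2CCCCC2)nn1-c1ccccc1`, has not yet been measured in this assay. It differs from compound 2 in a single place: piperidin-1-yl in place of ethylamino on a carbonyl carbon. Among the measured compounds shown here, no measured pair shows the effect of this kind of change on its own, so the expectation is tentative: a small to moderate rise, which could also turn out to be none beyond the scatter. Compound 3 is expected to give 15% in this assay, with a likely range from 0% to 35%. The step of a number 15 percentage points higher from compound 2 to compound 3 (beyond the scatter) is accordingly expected to be modest and upward.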

Compound 3, a percentage reported as inhibition, in the whole organism at one dose (the size of the read-out at that dose, not a potency): 15.6%
The estimate for compound 3 lay 0.6 percentage points below the measured number; measured number inside the range.
By their numbers in this assay, from the lowest: compound 2; then compound 3; then compound 1.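

In this assay, among the compounds shown here, piperidin-1-yl in place of ethylamino on a carbonyl carbon gives a number 15.6 percentage points higher from compound 2 to compound 3 (beyond the scatter), the first change in a single place, and it shows that the group on this carbonyl carbon can by itself shift the inhibition seen in the whole animal. The change swaps an open group carrying a hydrogen-bond donor for a larger six-membered ring with none, so ring, size and donor all change at once, and this one step cannot separate them. Nothing measured here accounts for the rise.

Going by these compounds, it remains open whether an open-chain diethylamino group on the same carbonyl carbon would give a similar number, which would help separate the loss of the amide hydrogen from the presence of the ring. A morpholin-4-yl group there would likewise test whether a ring oxygen alters the result.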